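This account rests on a few compounds, and the source may have more. Where it says the series, first, only, none or still open, it means among the compounds named here.

Working notes on the quinazoline series. Compound 1 `COc1cc2c(Nc3ccc(C#N)cc3)ncnc2cc1OCCCN1CCC(C)CC1` is the reference; in a functional assay on A549 cells (Homo sapiens) for antiproliferative activity, read by MTT assay, with a stated time of 72 h (on this read-out lower numbers stand for stronger inhibition and higher numbers for weaker inhibition), compound 1 gives 32300 nM. Compound 2 `COc1cc2c(Nc3ccc(C#N)cc3)ncnc2cc1OCCCN1CCN(C)CC1` carries the change (4-methylpiperazin-1-yl in place of 4-methylpiperidin-1-yl on a saturated chain carbon, three bonds along the chain from an oxygen on an aromatic ring); in this assay compound 2 gives 48800 nM, a step of a 1.5-fold higher number from compound 1 to compound 2 (0.18 log units; within the scatter). Compound 3 `COc1cc2c(Nc3ccccc3C#N)ncnc2cc1OCCCN1CCC(C)CC1` differs from compound 1 in the core by 2-cyanophenyl in place of 4-cyanophenyl on a nitrogen on an aromatic ring; in this assay compound 3 gives 22700 nM, a step of a 1.4-fold lower number from compound 1 to compound 3 (0.15 log units; within the scatter). Compound 3 holds the lowest of the three numbers, yet its gap to compound 1 is within the scatter and only its gap to compound 2 is beyond it, so no ranking of compound 3 against compound 1 is claimed.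

Compound 4 `COc1cc2c(Nc3ccccc3C#N)ncnc2cc1OCCCN1CCN(C)CC1` is not yet measured. It differs from compound 3 by 4-methylpiperazin-1-yl in place of 4-methylpiperidin-1-yl on a saturated chain carbon, three bonds along the chain from an oxygen on an aromatic ring. This is the same change as from compound 1 to compound 2, made on the same place, and it occurs only twice among the compounds shown. Because that earlier instance gave a 1.5-fold higher number from compound 1 to compound 2 (0.18 log units; within the scatter), compound 4 is expected to move from compound 3 by about the same small amount, a 1.5-fold higher number from compound 3 to compound 4 (0.18 log units; within the scatter), in this assay. A single prior instance is thin ground, so the range is kept wide. Compound 4 is estimated at 34000 nM in this assay. The expected span for compound 4 runs from 15000 nM to 80000 nM.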

Compound 4, half-maximal inhibitory concentration: 23400 nM
Compound 4: middle estimate off by 1.5-fold (0.16 log units), on the high side; the measured number falls inside the stated range.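

In this assay, 4-methylpiperazin-1-yl in place of 4-methylpiperidin-1-yl gives a 1.0-fold higher number from compound 3 to compound 4 (0.01 log units; within the scatter), and this step does not differ from its earlier instance on the core of compound 1: the same change on two cores in this assay, a 1.5-fold higher number (0.18 log units; within the scatter) from compound 1 to compound 2 and a 1.0-fold higher number (0.01 log units; within the scatter) from compound 3 to compound 4, 1.5-fold (0.17 log units) apart, within the scatter of two such steps

The change of 2-cyanophenyl in place of 4-cyanophenyl gives a 2.1-fold lower number from compound 2 to compound 4 (0.32 log units; beyond the scatter), and although only this instance lies beyond the scatter, the two instances do not differ from each other: the same change on two cores in this assay, a 1.4-fold lower number (0.15 log units; within the scatter) from compound 1 to compound 3 and a 2.1-fold lower number (0.32 log units; beyond the scatter) from compound 2 to compound 4, 1.5-fold (0.17 log units) apart, within the scatter of two such steps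

For the compounds shown here, both changes therefore carry from one core to the other in these four compounds with no detectable difference in size, so the 2-cyanophenyl step being within the scatter in one instance and beyond it in the other is no sign that it depends on the core; with only two instances of each change, in a single assay, this does not show that the steps are additive across the series or explain any of them.

The compounds shown leave open how a different amine at the end of the chain, such as morpholin-4-yl, or a longer chain would behave. They also leave open whether an amide or a carboxylic acid in place of the nitrile would shift the numbers on either core.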